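Third methoxy on the benzylamine arm of the quinoxaline series

The source may report more compounds than this note shows. Statements on the series, on what has been measured and on what is new or still open speak of the compounds shown alone.

Compound 2 `COc1ccc(CNc2nc3cc(N)cc(N)c3nc2-c2ccccc2)cc1OC` gives 30200 nM in a functional assay on EKVX cells (Homo sapiens) for inhibition, read by sulforhodamine B assay, with a stated time of 48 h; a lower number here means a stronger inhibitor of growth, a higher number a weaker inhibitor of growth; compound 1 `Nc1cc(N)c2nc(-c3ccccc3)c(NCc3ccc(Cl)c(Cl)c3)nc2c1` gives 38900 nM in this assay, and the two sit within the scatter of each other, so neither can be called the stronger inhibitor. Going by the values given here, the one measured step, a 1.3-fold lower number from compound 1 to compound 2 (0.11 log units; within the scatter), exchanges both halogens of the aryl ring for methoxy groups without a change beyond the scatter. Compound 3 `COc1cc(CNc2nc3cc(N)cc(N)c3nc2-c2ccccc2)cc(OC)c1OC` is not yet measured; it differs from compound 2 by methoxy in place of hydrogen on an aromatic carbon. Among the compounds with values here, no measured step adds a group to this ring position, so the only guide is that the swap of substituents on the same ring left the number essentially unchanged, and a further methoxy is expected to do little. A step of about a 1.1-fold lower number from compound 2 to compound 3 (0.03 log units; within the scatter) is therefore expected, with the estimate for compound 3 put at 28000 nM in this assay, within 10000 nM to 80000 nM.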

Compound 3, concentration for total growth inhibition: 8320 nM
Compound 3: the middle estimate sits 3.4-fold (0.53 log units) above what was measured, and the stated range ends above it.
By their numbers in this assay, from the lowest: compound 3; then compounds 2 and 1 (each within the scatter of the next).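

Going by these compounds alone, this aromatic carbon, ortho to a methoxy group and meta to a large group, is the first place where a change moves the number in this assay beyond the scatter (a 3.6-fold lower number from compound 2 to compound 3 (0.56 log units; beyond the scatter)). The earlier change on the same ring (a 1.3-fold lower number from compound 1 to compound 2 (0.11 log units; within the scatter)) stayed within the scatter, so the added methoxy shows what that exchange of substituents did not: this ring can respond to substitution, if only modestly so far. No evidence on hand accounts for the size of the step.

The compounds shown leave open whether the lower number is specific to methoxy or would also follow from hydroxyl, ethoxy or an amine at this carbon. They also leave open whether the step depends on the two methoxy groups already on the ring.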